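The compounds below may be only part of what the source reports. "The series", "measured", "known", "first", "only" and "open" are said of these compounds alone.

In a functional assay on the whole organism (Tail, strain ICR) with Mus musculus as the target, in the tail flick test, with a stated time of 150 min, at a dose of 25 umol/kg by the oral route (on this read-out lower numbers stand for a weaker effect and higher numbers for a stronger effect at the one dose given), compound 1, `CSCC[C@H](NC(=O)CN(c1nc(Cl)nc2[nH]cnc12)C1CC1)C(=O)OCc1ccccc1`, gives 17.6%, and compound 2, `NCCCC[C@H](NC(=O)CN(c1nc(Cl)nc2[nH]cnc12)C1CC1)C(=O)OCc1ccccc1`, gives 9.88%. The gap between them, a number 7.7 percentage points lower from compound 1 to compound 2 (within the scatter), is within the scatter, so compound 2 does not stand apart from compound 1 on these two numbers. Compound 3, `O=C(CN(c1nc(Cl)nc2[nH]cnc12)C1CC1)NCC(=O)OCc1ccccc1`, differs from compound 2 by hydrogen in place of 4-aminobutyl on a saturated chain carbon bound to an amide-type nitrogen and a carbonyl carbon. Going by the values given here, the only measured step, a number 7.7 percentage points lower from compound 1 to compound 2 (within the scatter), bears on this change: it put 2-aminoethyl in place of methylsulfanyl on a saturated chain carbon and left the read-out within the scatter. Compound 3 drops the 4-aminobutyl group altogether, a broader change than that exchange, yet nothing measured here points to a shift beyond the scatter in either direction. The expected step is therefore a number 0.9 percentage points lower from compound 2 to compound 3 (within the scatter), within the scatter. For compound 3 the estimate in this assay is 9%, with a range from 0% to 22%.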

Compound 3, a percentage reported as activity, at one dose (the size of the read-out at that dose, not a potency): 18%
The estimate for compound 3 lay 9 percentage points below the measured number; low and high end bracket the measured number.
By their numbers in this assay, from the lowest: compounds 2, 1 and 3 (each within the scatter of the next).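

In this assay, the new result tests the position with no side chain at all: hydrogen in place of 4-aminobutyl on a saturated chain carbon bound to an amide-type nitrogen and a carbonyl carbon gives a number 8.1 percentage points higher from compound 2 to compound 3 (within the scatter), and hydrogen in place of 2-(methylsulfanyl)ethyl at that carbon gives a number 0.4 percentage points higher from compound 1 to compound 3 (within the scatter). Earlier, only two side chains could be compared, whereas these steps show that, at this one dose, removing either one leaves the read-out within the scatter, so neither group is shown to be needed for it. Nothing available explains why these three compounds lie so close.

On these data alone, whether a carboxylic acid or a phenyl ring carried on this carbon would move the read-out beyond the scatter stays open. A longer chain ending in an amine is equally untested, and so is whether the three compounds would stay this close at another dose.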